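The compounds below may be only part of what the source reports. "The series", "measured", "known", "first", "only" and "open" are said of these compounds alone.

Measured compounds:
- compound 1 `O=C(Nc1cccc(-n2cc(-c3ccncc3)c(-c3cc(O)cc(Cl)c3)n2)c1)Nc1ccc(Cl)c(C(F)(F)F)c1` — -33%
- compound 2 `COc1cc(Cl)cc(-c2nn(-c3cccc(NC(=O)Nc4ccc(Cl)c(C(F)(F)F)c4)c3)cc2-c2ccncc2)c1` — -25%
- compound 3 `COc1cc(Cl)cc(-c2nn(-c3cccc(NC(=O)Nc4cc(C(F)(F)F)cc(C(F)(F)F)c4)c3)cc2-c2ccncc2)c1` — -42%

In a functional assay on SNB-19 cells (Homo sapiens) for inhibition, read by sulforhodamine B assay, with a stated time of 48 h, tested at 100 uM (on this read-out lower numbers stand for a stronger effect and higher numbers for a weaker effect at the one concentration tested), compound 2 gives the highest of the three numbers. Its nearest neighbour is compound 1, from which it differs by the step of a number 8 percentage points higher from compound 1 to compound 2 (within the scatter), a step within the scatter. For the measured compounds named here, compound 3 stands furthest from compound 2, with a number beyond the scatter lower; no single-point step between these two is defined, so only the two values themselves can be compared.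

The next compound, compound 4 `COc1cc(Cl)cc(-c2nn(-c3cccc(NC(=O)c4cccc(C(F)(F)F)c4)c3)cc2-c2ccncc2)c1`, is unmeasured. The change from compound 2 to compound 4 is 3-(trifluoromethyl)phenyl in place of (4-chloro-3-(trifluoromethyl)phenyl)amino on a carbonyl carbon. Going by the values given here, no measured step bears on this change: the only step on record, a number 8 percentage points higher from compound 1 to compound 2 (within the scatter), concerns a different part of the molecule, and all three measured compounds carry the same urea-type linkage that compound 4 loses. Without any comparable step, the expectation for this assay must be wide. On balance a step upward, toward a weaker effect, is expected, with a number 20 percentage points higher from compound 2 to compound 4 (beyond the scatter) as the estimated size, but a result within the scatter of compound 2 is also plausible. For compound 4 the estimated value is -5%, with a range from -40% to 30%.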

Compound 4, a percentage reported as activity, at one concentration (the size of the read-out at that concentration, not a potency): 72%
For compound 4 the middle estimate is 77 percentage points below the measured one; the whole stated range lies below it.
By their numbers in this assay, from the lowest: compounds 3, 1 and 2 (each within the scatter of the next, the first and the last beyond it); then compound 4.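

In this assay, for the compounds shown here, the group on the carbonyl carbon is the first place where a single change moves the read-out beyond the scatter: the step (a number 97 percentage points higher from compound 2 to compound 4 (beyond the scatter)) points to a much weaker effect, whereas the change on the aromatic oxygen (a number 8 percentage points higher from compound 1 to compound 2 (within the scatter)) stayed within the scatter. The position is therefore highly sensitive to this replacement, which removes the (4-chloro-3-(trifluoromethyl)phenyl)amino group, with its hydrogen-bond donor and its chlorine, and puts 3-(trifluoromethyl)phenyl directly on the carbonyl carbon. No supporting measurement is available to explain the size of this step.

As far as these compounds go, the step changes the amino nitrogen and the chlorine together, so the share of each remains open; (3-(trifluoromethyl)phenyl)amino on the same carbonyl carbon would keep the nitrogen without the chlorine, and 4-chloro-3-(trifluoromethyl)phenyl would keep the chlorine without the nitrogen. Also open, from the compounds shown here alone, is whether the nitrogen can be replaced by another single atom, as with a benzyl group on the carbonyl carbon, and whether the same step would hold on a different aryl group.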